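The source may report more compounds than this note shows. Statements on the series, on what has been measured and on what is new or still open speak of the compounds shown alone.

Of the compounds shown here, two with a shared core have been measured so far in an ADME assay on microsomes from liver (Homo sapiens) for metabolic stability, with a stated time of 60 min, tested at 1 uM; a higher number here means that more of the compound is left, a lower number that less of the compound is left. Compound 1 (`COc1cc(-c2cnn3cc(OC)c(-c4cc(C)no4)nc23)ccn1`) gives 31%, and compound 2 (`COc1cc(-c2cnn3cc(OC)c(C)nc23)ccn1`) gives 44%, the higher of the two numbers. Compound 3 (`COc1cnc2c(-c3ccnc(OC)c3)cnn2c1`) has not yet been measured. Its difference from compound 2 is hydrogen in place of methyl on an aromatic carbon. For the measured compounds named here, only one measured step bears on this change, and it does so indirectly. That step is a number 13 percentage points higher from compound 1 to compound 2 (beyond the scatter), with methyl in place of 3-methyl-1,2-oxazol-5-yl on the same aromatic carbon. It is modest, and it comes from a single pair of compounds. Going by the values given here, no measured step shows what hydrogen does at this carbon, and the change to compound 3 removes far less than the change to compound 2 did. A small rise is therefore expected, in the same direction as the measured step, and it may not clear the scatter. The expected step is a number 6 percentage points higher from compound 2 to compound 3 (within the scatter). For compound 3 the estimated value is 50%, with an expected range from 30% to 70%.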

Compound 3, percent of the compound remaining: 2%
Compound 3: middle estimate off by 48 percentage points, on the high side; measured number outside the range, below it.
By their numbers in this assay, from the lowest: compound 3; then compound 1; then compound 2.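

In this assay, the aromatic carbon that carries the methyl group turns out to be far more sensitive than the earlier pair could show: with hydrogen in place of methyl there is a number 42 percentage points lower from compound 2 to compound 3 (beyond the scatter) and this large step is the biggest of the three. Replacing the 3-methyl-1,2-oxazol-5-yl group with hydrogen likewise gives a number 29 percentage points lower from compound 1 to compound 3 (beyond the scatter) so both compounds with a group on this carbon stand above the compound with hydrogen, while the group with more atoms, in compound 1, does not give the highest number, which goes to the methyl of compound 2. The compounds shown offer no information that explains why the number falls so far when the methyl group is lost.

On these data alone, what remains open is how other groups on this carbon would read in this assay, such as an ethyl group, a fluorine atom or an amine, and whether any of them would stand above methyl. As far as these compounds go, it is also open whether the same large drop would appear if the ortho methoxy group were exchanged for a longer chain.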